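A sulfonyl group exchanged on compound 2

The source may report more compounds than this note shows. Statements on the series, on what has been measured and on what is new or still open speak of the compounds shown alone.

In a functional assay on MCF7 cells (Homo sapiens) for antiproliferative activity, read by MTT assay, with a stated time of 24 h (a higher number here means a weaker inhibitor, a lower number a stronger inhibitor), compound 1 (`Cc1ccc(-c2nn(-c3ccccc3)cc2-c2nc3ccccc3n2S(=O)(=O)c2cc(C)ccc2C)cc1`) gives 510 nM and compound 2 (`COc1ccc(S(=O)(=O)n2c(-c3cn(-c4ccccc4)nc3-c3ccc(F)cc3)nc3ccccc32)cc1`) gives 530 nM as its reading, so compound 2 stands level with compound 1 within the scatter. Compound 3 (`Cc1ccc(C)c(S(=O)(=O)n2c(-c3cn(-c4ccccc4)nc3-c3ccc(F)cc3)nc3ccccc32)c1`) differs from compound 2 in one place, with 2,5-dimethylphenyl in place of 4-methoxyphenyl on a sulfonyl sulfur as the change, on a sulfonyl sulfur. Within the data shown here, no measured pair of compounds shows what this exchange does, so no shift beyond the scatter is expected in either direction. The expected step of a 1.1-fold lower number from compound 2 to compound 3 (0.03 log units; within the scatter) stays within the scatter. Compound 3 is estimated at 500 nM with 230 nM to 1100 nM as the expected range.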

Compound 3, half-maximal inhibitory concentration: 430 nM
Compound 3: the middle estimate sits 1.2-fold (0.07 log units) above what was measured, within the range that was stated.
By their numbers in this assay, from the lowest: compounds 3, 1 and 2 (each within the scatter of the next).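

In this assay the exchange of 4-methoxyphenyl for 2,5-dimethylphenyl on a sulfonyl sulfur gives a 1.2-fold lower number from compound 2 to compound 3 (0.09 log units; within the scatter) and so moves the reading by no more than the scatter, even though the oxygen of the methoxy group is gone. With 2,5-dimethylphenyl held on the sulfonyl sulfur, fluoro in place of methyl on an aromatic carbon gives a 1.2-fold lower number from compound 1 to compound 3 (0.07 log units; within the scatter) and likewise stays inside the scatter. Nothing measured here bears on why these readings lie so close. The compounds shown leave open whether a methyl group alone on the sulfonyl sulfur, or a phenyl ring carrying an amine or a carboxylic acid, would shift the number beyond the scatter.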